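The source may report more compounds than this note shows. Statements on the series, on what has been measured and on what is new or still open speak of the compounds shown alone.

In a functional assay on HL-60 cells (Homo sapiens) for antiproliferative activity, with a stated time of 72 h (on this read-out lower numbers stand for stronger inhibition and higher numbers for weaker inhibition), three compounds sharing one core have been measured. Compound 1 (`COc1cc(OC)c(C(=O)/C=C/c2ccccc2Cl)c(O)c1CN1CCCCC1`) gives 3600 nM, compound 2 (`CCN(C)Cc1c(OC)cc(OC)c(C(=O)/C=C/c2ccccc2Cl)c1O`) gives 200 nM, and compound 3 (`COc1cc(OC)c(C(=O)/C=C/c2ccccc2Cl)c(O)c1CN(C)CCCN(C)C`) gives 11400 nM, the highest number and so the weakest of the three. Compound 4 (`COc1cc(OC)c(C(=O)/C=C/c2ccccc2Cl)c(O)c1CN(C)C`) differs from compound 3 by hydrogen in place of 2-(dimethylamino)ethyl on a saturated chain carbon bound to an amine nitrogen, which leaves a dimethylamino group. The closest measured change is the large 57-fold higher number from compound 2 to compound 3 (1.76 log units; beyond the scatter), and the new change runs roughly in reverse, towards an amine resembling that of compound 2. The large 18-fold lower number from compound 1 to compound 2 (1.26 log units; beyond the scatter) shows that the choice of amine can matter greatly here. A large fall is therefore expected, a 29-fold lower number from compound 3 to compound 4 (1.45 log units; beyond the scatter). Compound 4 is estimated at 400 nM, with an expected range from 100 nM to 2000 nM.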

Compound 4, half-maximal inhibitory concentration: 19200 nM
Compound 4: middle estimate off by 48-fold (1.68 log units), on the low side, and the stated range ends below it.
By their numbers in this assay, from the lowest: compound 2; then compound 1; then compounds 3 and 4 (each within the scatter of the next).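

With hydrogen in place of 2-(dimethylamino)ethyl, the numbers lie within the scatter of each other (a 1.7-fold higher number from compound 3 to compound 4 (0.23 log units; within the scatter)), so the extra amine chain of compound 3 shows no measurable effect here. By contrast, hydrogen in place of methyl on the saturated chain carbon bound to the amine nitrogen, the ethyl of compound 2 becoming the methyl of compound 4, gives a large step (a 96-fold higher number from compound 2 to compound 4 (1.98 log units; beyond the scatter)). The piperidine also separates modestly (a 5.3-fold higher number from compound 1 to compound 4 (0.73 log units; beyond the scatter)). Open, from the compounds shown here alone, is whether a diethylamino or propyl(methyl)amino group would match compound 2 or exceed it. No measurement shown explains the large effect of that one carbon.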